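The source may report more compounds than this note shows. Statements on the series, on what has been measured and on what is new or still open speak of the compounds shown alone.

Compound 1, `COc1ccc(S(=O)(=O)c2cnc3cc(Cl)ccc3c2N2CCC(C)CC2)cc1Cl`: 93%
Compound 2, `CC1CCN(c2c(S(=O)(=O)c3cc(Cl)cc(Cl)c3)cnc3cc(Cl)ccc23)CC1`: 93%

Both measured compounds were tested in an assay on isolated protein for displacement of a labelled ligand from metabotropic glutamate receptor 5 (Homo sapiens), with a stated time of 60 min, tested at 1 uM; on this read-out lower numbers stand for less inhibition and higher numbers for more inhibition at the one concentration tested (going by the name of the read-out). In this assay compound 1 gives 93%, and compound 2 gives 93%, so compound 2 stands level with compound 1 within the usual scatter. Going by the values given here, the only measured step, no change at the digits printed from compound 1 to compound 2 (within the scatter), placed 3,5-dichlorophenyl in place of 3-chloro-4-methoxyphenyl on a sulfonyl sulfur and left the read-out unchanged.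

Compound 3, `Cc1ccc(S(=O)(=O)c2cnc3cc(Cl)ccc3c2N2CCC(C)CC2)cc1C`, has not yet been measured in this assay. It differs from compound 2 in one place: 3,4-dimethylphenyl in place of 3,5-dichlorophenyl on a sulfonyl sulfur. Among the compounds with values here, the one step measured so far bears on it directly, since it too exchanged the group on the same sulfonyl sulfur, and it produced no change beyond the scatter. The expectation is therefore a step of a number 5 percentage points lower from compound 2 to compound 3 (within the scatter) that stays within the scatter, with at most a small move downward given that compound 2 already sits near the top of the scale. Compound 3 is estimated at 88%, with a likely range from 72% to 97%.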

Compound 3, a percentage reported as inhibition, at one concentration (the size of the read-out at that concentration, not a potency): 86%
Beside the measured number, compound 3's estimate is 2 percentage points above it; measured number inside the range.
By their numbers in this assay, from the lowest: compounds 3, 1 and 2 (each within the scatter of the next).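

In this assay, the read-out shows a number 7 percentage points lower from compound 2 to compound 3 (within the scatter) when 3,4-dimethylphenyl, with 8 carbon atoms and no chlorine, replaces 3,5-dichlorophenyl on the sulfonyl sulfur. Against the third group tried at this position, the comparison gives a number 7 percentage points lower from compound 1 to compound 3 (within the scatter) for 3,4-dimethylphenyl in place of 3-chloro-4-methoxyphenyl, so compounds 1, 2 and 3 cannot be told apart here. The earlier pair had both carried chlorine on this ring, whereas compound 3 shows that, among these three compounds, chlorine on the ring is not needed for a high read-out at the single concentration tested, and nothing measured here explains why.

All three values lie close together near the top of the scale at one concentration, so real differences in potency between these aryl groups could stay hidden, and a full concentration series would be needed to reveal them. As far as these compounds go, it also remains open whether the position would accept a very different group on the sulfonyl sulfur, such as a phenyl ring bearing a carboxylic acid or an amine, or a plain alkyl chain in place of the ring.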